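Extending the Chain on the Aryl Urea Series

The source may report more compounds than this note shows. Statements on the series, on what has been measured and on what is new or still open speak of the compounds shown alone.

The measured compounds:
compound 1, `Cc1ccccc1NC(=O)N[C@@H](C)c1ccccc1`, 100% in an ADME assay on the whole organism with Oryza sativa as the target, tested at 0.1 uM; a lower number here means a stronger effect, a higher number a weaker effect of the compound at the concentration tested
compound 2, `CCc1ccc(NC(=O)N[C@H](C)c2ccccc2)cc1`, 95%
compound 3, `CCc1ccc(NC(=O)N[C@@H](C)c2ccccc2)cc1`, 99%

Among these three, compound 2 has the lowest number, yet its nearest neighbour, compound 3, and its furthest, compound 1, both lie within the scatter of it, so the three values cannot be ranked against one another. Going by the values given here, the only step between compounds differing in one place is a number 4 percentage points higher from compound 2 to compound 3 (within the scatter), which rests on the fact that compounds 2 and 3 differ only in the configuration as drawn and says nothing about changing the size of a substituent.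

The unmeasured compound 4, `CCCCCCCc1ccc(NC(=O)N[C@H](C)c2ccccc2)cc1`, differs from compound 2 as follows: pentyl in place of hydrogen on a saturated chain carbon, two bonds along the chain from an aromatic carbon. Among the compounds with values here, no measured step concerns a change of this kind; the single step available, from a change of configuration, was itself within the scatter. There is therefore no basis for predicting a move in either direction, and the expectation is a step of a number 2 percentage points lower from compound 2 to compound 4 (within the scatter), that is, none beyond the scatter. Compound 4 is accordingly estimated at 93%, with a range from 70% to 100%, the upper end being bounded by the full read-out already shown by compound 1.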

Compound 4, a percentage reported as activity, at one concentration (the size of the read-out at that concentration, not a potency): 100%
For compound 4 the middle estimate is 7 percentage points below the measured one; low and high end bracket the measured number.
By their numbers in this assay, from the lowest: compounds 2, 3, 1 and 4 (each within the scatter of the next).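

At this place, on a saturated chain carbon, two bonds along the chain from an aromatic carbon, pentyl in place of hydrogen gives a number 5 percentage points higher from compound 2 to compound 4 (within the scatter) in this assay. The earlier compounds shown here offered only a step in configuration, whereas this step concerns the size of the group and shows that the difference that also reads as ethyl to heptyl leaves compound 4 within the scatter of compound 2, so neither this step nor the earlier one shows a real change in the read-out. Nothing available bears on why this longer chain gives this result.

The compounds shown leave open whether a different group at this place, such as an amine, a carboxylic acid or a phenyl ring, would give a step beyond the scatter, and whether a shorter chain such as propyl would behave as heptyl does. They also leave open whether the heptyl compound with the opposite configuration at the stereocentre would read as compound 4 does.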